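Dropping the Chloro Group: What Compound 3 Should Tolerate

This account rests on a few compounds, and the source may have more. Where it says the series, first, only, none or still open, it means among the compounds named here.

Compound 1 `CCN(CC)CN1C(=O)/C(=N/NC(N)=S)c2cc(Cl)ccc21` gives 78300 nM in an ADME assay on MDCK cells (Canis lupus familiaris) for cytotoxicity; a lower number here means that less compound is tolerated, a higher number that more compound is tolerated.
Compound 2 `CCN(CC)CN1C(=O)/C(=N/NC(=S)Nc2ccc(Cl)cc2)c2cc(Cl)ccc21` gives 2400 nM in this assay.

For the measured compounds named here, compound 2 holds the lowest of the two numbers measured so far, and its only neighbour is compound 1, separated from it by a 33-fold lower number from compound 1 to compound 2 (1.51 log units; beyond the scatter). Compound 3 `CCN(CC)CN1C(=O)/C(=N/NC(=S)Nc2ccccc2)c2cc(Cl)ccc21` is the next compound, and it differs from compound 2 by hydrogen in place of chloro on an aromatic carbon, the 4-chlorophenyl becoming a plain phenyl. Going by the values given here, the one measured step concerns a different change, the 4-chlorophenyl replacing hydrogen on the amide-type nitrogen, and no measured pair shows a chloro removed from an aromatic carbon, so nothing directly bears on this step. The expectation is therefore a small shift, if any, most likely toward a higher number, with a 1.7-fold higher number from compound 2 to compound 3 (0.22 log units; within the scatter) quite possibly staying within the scatter. Compound 3 is thus estimated at 4000 nM, in a range from 1500 nM to 12000 nM.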

Compound 3, half-maximal cytotoxic concentration: 3000 nM
Compound 3: middle estimate off by 1.3-fold (0.12 log units), on the high side; the measured number falls inside the stated range.
By their numbers in this assay, from the lowest: compounds 2 and 3 (each within the scatter of the next); then compound 1.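

In this assay the chloro on an aromatic carbon, para to a large group, gives way to hydrogen with a 1.3-fold higher number from compound 2 to compound 3 (0.10 log units; within the scatter) and so leaves compound 2 and compound 3 level within the scatter. The plain phenyl on the amide-type nitrogen still brings a 26-fold lower number from compound 1 to compound 3 (1.42 log units; beyond the scatter) and shows that, among these compounds, the large step does not depend on the chloro but comes with the aromatic ring itself. Nothing available explains either result.

As far as these compounds go, it remains open whether a methoxy group or a carboxylic acid at that same ring carbon would also leave the number level with compound 3. From the compounds shown here alone, it is equally open whether a short alkyl chain such as ethyl, in place of the phenyl on that nitrogen, would bring a step as large as the phenyl does.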